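The source may hold more compounds than are shown below. What is called first, only, known or untested is meant among the compounds shown, and "the series" means these compounds.

Measured in a functional assay on Jurkat cells (Homo sapiens) for inhibition, read by CCK-8 assay, with a stated time of 48 h; on this read-out lower numbers stand for stronger inhibition of growth and higher numbers for weaker inhibition of growth:
- compound 1 `Cc1ccccc1Nc1nc(NC2CCCCC2)ncc1Cl`: > 100000 nM
- compound 2 `Cc1ccccc1Nc1nc(Nc2ccccc2)ncc1Cl`: > 100000 nM
- compound 3 `Cc1ccccc1Nc1nc(NCc2ccccc2)ncc1Cl`: > 100000 nM

Each of these entries is a limit and not a number, and the whole picture is the limit of > 100000 nM in this assay, at which 3 of the 3 values shown sit. Compound 2 therefore has no exact position, only its limit of > 100000 nM.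

Compound 4 `Cc1ccccc1Nc1nc(Nc2ccc(N3CCCCC3)cc2)ncc1Cl` has piperidin-1-yl in place of hydrogen on an aromatic carbon.

The measured steps that bear on this are a step that the two limits leave unreadable from compound 1 to compound 2, a step that the two limits leave unreadable from compound 1 to compound 3 and a step that the two limits leave unreadable from compound 2 to compound 3. None of them gives a size to carry over, so any forecast is loose. A shift towards stronger inhibition of growth in this assay is expected, though compound 4 may well stay at the limit. The expected change is an at least 2.5-fold lower number from compound 2 to compound 4 (0.39 log units; beyond the scatter). For compound 4 the estimated value is 40000 nM, with an expected range from 5000 nM to 100000 nM.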

Compound 4, concentration for 50% growth inhibition: > 100000 nM
Compound 4 was reported as a limit; the forecaster's own chance of this, stated with the estimate: 50%; at least 2.5-fold (0.39 log units) between middle value and limit.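

Within the data shown here, compound 2 and compound 4 are both reported as a limit and not a number, so no step between them can be read: the limit of > 100000 nM in this assay, at which 4 of the 4 values shown sit.

The compounds shown leave open whether piperidin-1-yl or any other group shown changes growth inhibition in this assay at all.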